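A few compounds are considered here, and "the series" means these few. Any claim that something is new, unique, unknown or untested is made for them only; others in the source may bear on it.

Of the compounds shown here, three that share one core have been measured in an assay on HEK293 cells for positive allosteric modulation of metabotropic glutamate receptor 2 (Rattus norvegicus), read by thallium flux, with a stated time of 2.5 min; a higher number here means that more compound is needed for the effect, a lower number that less compound is needed. Compound 1 `Cc1cc(C(=O)O)ccc1OCCCCOc1ccc(C(=O)CC(C)C)c(O)c1C` gives 192 nM in this assay. Compound 2 `CCC(=O)c1ccc(OCCCCOc2ccc(C(=O)O)cc2C)c(C)c1O` gives 82 nM, and compound 3 `Cc1cc(C(=O)O)ccc1OCCCCOc1ccc(C(=O)CC2CCCC2)c(O)c1C` gives 608 nM. Compound 1 thus stands second highest of the three numbers: its nearest neighbour is compound 2, with a 2.3-fold lower number from compound 1 to compound 2 (0.37 log units; beyond the scatter), and its furthest is compound 3, with a 3.2-fold higher number from compound 1 to compound 3 (0.50 log units; beyond the scatter). Compound 4 `Cc1c(OCCCCOc2ccc(F)c(C(=O)O)c2)ccc(C(=O)CC(C)C)c1O` has not yet been measured. It differs from compound 1 in one place: 3-carboxy-4-fluorophenyl in place of 4-carboxy-2-methylphenyl on an oxygen on a saturated carbon. Among the compounds with values here, every measured step so far changes only what sits on the saturated chain carbon bound to a carbonyl carbon, for example a 7.4-fold higher number from compound 2 to compound 3 (0.87 log units; beyond the scatter); none of them alters the group carried by the oxygen on a saturated carbon, so no measured step bears directly on this change, and the direction is open. Without a guiding step, the expected step is a 1.6-fold higher number from compound 1 to compound 4 (0.19 log units; within the scatter), a modest shift toward a higher number with wide uncertainty. Compound 4 is therefore estimated to give about 300 nM in this assay, within a range from 100 nM to 1000 nM.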

Compound 4, half-maximal effective concentration: 153 nM
Compound 4: middle estimate off by 2.0-fold (0.29 log units), on the high side; the range from low to high includes it.
By their numbers in this assay, from the lowest: compounds 2, 4 and 1 (each within the scatter of the next, the first and the last beyond it); then compound 3.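

Within the data shown here, this is the first measured step at the group on the oxygen on a saturated carbon, and in this assay putting 3-carboxy-4-fluorophenyl in place of 4-carboxy-2-methylphenyl gives a 1.3-fold lower number from compound 1 to compound 4 (0.10 log units; within the scatter). Although the two groups differ in both their substituents and where the carboxy group stands, the numbers for these two compounds cannot be told apart, whereas changing the group on the saturated chain carbon bound to a carbonyl carbon gives a 7.4-fold higher number from compound 2 to compound 3 (0.87 log units; beyond the scatter). Nothing shown here explains why this swap leaves the number within the scatter.

The swap changes several features at once, so the separate contributions of the methyl, the fluorine and the carboxy placement remain unresolved, and they could offset one another. Also open, on these data alone, is how the number would respond if a primary amide or a nitrile stood in place of the carboxylic acid on this ring.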